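The compounds below may be only part of what the source reports. "The series", "measured", "known", "first", "only" and "open" are said of these compounds alone.

Working notes on the series. Of the compounds shown here, three sharing one core have solubility numbers so far. Compound 1 `COc1cc(NC(C)CCCN2C(=O)[C@@H](C)N(C(=O)CN)C2(C)C)c2ncccc2c1` gives 110000 ug/mL in a physicochemical assay for solubility; on this read-out lower numbers stand for lower solubility and higher numbers for higher solubility. Among the compounds with values here, compound 3 `COc1cc(NC(C)CCCN2C(=O)[C@@H](C)NC2(C)C)c2ncccc2c1` gives 29800 ug/mL in this assay, and the one-place step between them, a 3.7-fold lower number from compound 1 to compound 3 (0.57 log units; beyond the scatter), is the only measured step in the set. Compound 2 `COc1cc(NC(C)CCCN2C(=O)CN(C(=O)[C@H](N)CC(C)C)C2(C)C)c2ncccc2c1` gives 26600 ug/mL in this assay; it holds the lowest of the three numbers, sits within the scatter of compound 3 and lies beyond the scatter only against compound 1.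

Compound 4 `CC[C@H](C)[C@@H](N)C(=O)N1CC(=O)N(CCCC(C)Nc2cc(OC)cc3cccnc23)C1(C)C` is not yet measured. It differs from compound 2 by sec-butyl in place of isobutyl on a saturated chain carbon bound to an amine nitrogen and a carbonyl carbon; the two have the same atoms, joined differently. Within the data shown here, no measured step touches this position: the step from compound 1 to compound 3 concerns the acyl group on the ring amine nitrogen, not the side chain of the acyl group, so it does not bear on this change. With no heavy atom, donor, acceptor or charge added or removed, no step beyond the scatter is expected, and the estimated step of a 1.1-fold lower number from compound 2 to compound 4 (0.03 log units; within the scatter) is near nil. Compound 4 is expected at about 25000 ug/mL, with a range of 12000 ug/mL to 50000 ug/mL.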

Compound 4, solubility: 29700 ug/mL
For compound 4 the middle estimate is 1.2-fold (0.07 log units) below the measured one; the measured number falls inside the stated range.
By their numbers in this assay, from the lowest: compounds 2, 4 and 3 (each within the scatter of the next); then compound 1.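

At the saturated chain carbon bound to an amine nitrogen and a carbonyl carbon, this assay now gives a first reading: a 1.1-fold higher number from compound 2 to compound 4 (0.05 log units; within the scatter) for sec-butyl in place of isobutyl. The step from compound 1 to compound 3 concerned the acyl group as a whole, whereas this pair shows that rejoining the same four carbons in this side chain, with the sec-butyl carrying 1 defined stereocentre, gives no step beyond the scatter. Nothing available offers an explanation for this result.

As far as these compounds go, whether an amine, a carboxylic acid or a longer chain at this position would give a step beyond the scatter remains open. Also open, from the compounds shown here alone, is whether sec-butyl in place of isobutyl reads the same on other variants of the shared core.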